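This account rests on a few compounds, and the source may have more. Where it says the series, first, only, none or still open, it means among the compounds named here.

Three compounds have been measured in a toxicity assay on THP-1 cells (Homo sapiens) for inhibition; on this read-out higher numbers stand for lower toxicity in this test and lower numbers for higher toxicity in this test:

compound 1 `Cn1c(-c2cccc([N+](=O)[O-])c2)cnc1NC(=O)c1ccc(F)cc1`: > 50000 nM
compound 2 `COc1ccc2nc(NC(=O)c3ccc(F)cc3)n(C)c2c1`: > 100000 nM
compound 3 `COc1ccc(-c2cnc(NC(=O)c3ccccc3F)n2C)cc1`: > 100000 nM

Each of these readings is a limit of the assay rather than a number. Compound 1 stands at > 50000 nM, a limit, in this assay. Compound 2 returns > 100000 nM, likewise a limit. Compound 3 returns > 100000 nM, also a limit. Going by the values given here, two of the three readings sit at the limit of > 100000 nM in this assay, at which 2 of the 3 values shown sit, and the one for compound 1 sits at the limit of > 50000 nM in this assay, at which 1 of the 3 values shown sits. No two of these compounds differ in only one place, so no measured step exists among them; the values merely show that none of the three reaches a measurable toxicity in this assay.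

Compound 4 `Cn1c(-c2cccc(F)c2)cnc1NC(=O)c1ccc(F)cc1` has not yet been measured. It differs from compound 1 in one place: fluoro in place of nitro on an aromatic carbon. Among the compounds with values here, with no measured step to lean on, the size of the step from compound 1 to compound 4 in this assay can only be expected, and the expectation is for no change beyond the scatter, since compound 1 itself shows only a limit, > 50000 nM. Compound 4 is therefore expected to give 80000 nM in this assay, within a range from 30000 nM to 200000 nM, which means an expected step that the limit leaves unreadable from compound 1 to compound 4 and most likely a limit rather than a number once more.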

Compound 4, half-maximal cytotoxic concentration: 58000 nM
For compound 4 the middle estimate is 1.4-fold (0.14 log units) above the measured one; the measured number falls inside the stated range.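

Compound 4 gives a number, 58000 nM, but the step from compound 1 to compound 4 cannot be read in this assay. Compound 1 gives > 50000 nM, which is a limit. The compounds shown leave open how far fluoro in place of nitro on an aromatic carbon moves this read-out, if at all.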